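The compounds below may be only part of what the source reports. "The series", "measured", "known", "first", "only" and "open" are said of these compounds alone.

Measured in a functional assay on SK-MEL-28 cells (Homo sapiens) for cytotoxicity, read by MTT assay; on this read-out lower numbers stand for stronger inhibition and higher numbers for weaker inhibition:

compound 1, `O=S(=O)(NCCCNc1nccc(-c2c(-c3cccc(F)c3)nc3sccn23)n1)c1ccc(C(F)(F)F)cc1`, gives 11700 nM
compound 2, `O=S(=O)(NCCCNc1nccc(-c2c(-c3cccc(F)c3)nc3sccn23)n1)c1ccc(Cl)cc1`, gives 8450 nM
compound 3, `O=C(NCCNc1nccc(-c2c(-c3cccc(F)c3)nc3sccn23)n1)c1ccc(C(F)(F)F)cc1`, gives 9260 nM

Compound 4, `O=C(NCCNc1nccc(-c2c(-c3cccc(F)c3)nc3sccn23)n1)c1ccc(Cl)cc1`, has not yet been measured. It is made from compound 3 by chloro in place of trifluoromethyl on an aromatic carbon. The same change has already been measured once, from compound 1 to compound 2: chloro in place of trifluoromethyl on an aromatic carbon, which brought a 1.4-fold lower number from compound 1 to compound 2 (0.14 log units; within the scatter). The two place descriptions agree word for word, so this counts as the same change. How the core of compound 3 differs from the core of compound 1 is not broken down here; their values in this assay sit close together. For the measured compounds named here, the expected step is a 1.4-fold lower number from compound 3 to compound 4 (0.15 log units; within the scatter), because the earlier instance gave a 1.4-fold lower number from compound 1 to compound 2 (0.14 log units; within the scatter) and that is the only guide available. Compound 4 is therefore estimated at 6600 nM in this assay, with a likely range from 3000 nM to 14000 nM.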

Compound 4, half-maximal inhibitory concentration: 8160 nM
Compound 4: middle estimate off by 1.2-fold (0.09 log units), on the low side; measured number inside the range.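

In this assay, for the compounds shown here, chloro in place of trifluoromethyl on the aromatic ring gives much the same small step on both cores: the same change on two cores in this assay, a 1.4-fold lower number (0.14 log units; within the scatter) from compound 1 to compound 2 and a 1.1-fold lower number (0.05 log units; within the scatter) from compound 3 to compound 4, 1.2-fold (0.09 log units) apart, within the scatter of two such steps On either core the step stays within the scatter, as with a 1.1-fold lower number from compound 3 to compound 4 (0.05 log units; within the scatter), so this shows only that the swap leaves the number practically unmoved on these two cores, not that it has a real effect that transfers, and two cores cannot speak for the whole series. The cores themselves also stay within the scatter when compared directly, with a 1.0-fold lower number from compound 2 to compound 4 (0.02 log units; within the scatter), where ((4-chlorophenyl)carbonyl)amino stands in place of (((4-chlorophenyl)sulfonyl)amino)methyl.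

Still open, from the compounds shown here alone, is whether a different group at that ring position, such as an amine or a carboxylic acid, would shift the number beyond the scatter. The same question applies to a longer chain.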